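Trifluoromethyl for chloro on the urea aryl of compound 3

The compounds below may be only part of what the source reports. "The series", "measured", "known", "first", "only" and "open" are said of these compounds alone.

Series notes. Within the data shown here, the three measured members share one core. Compound 1 `COc1cc(-c2nn(-c3cccc(NC(=O)Nc4cc(C(F)(F)F)cc(C(F)(F)F)c4)c3)cc2-c2ccncc2)ccc1Cl` gives 933 nM in a functional assay on MCF7 cells (Homo sapiens) for inhibition, read by sulforhodamine B assay, with a stated time of 48 h; on this read-out higher numbers stand for weaker inhibition of growth and lower numbers for stronger inhibition of growth. Compound 2 `COc1cc(-c2nn(-c3cccc(NC(=O)Nc4ccc(Cl)c(Cl)c4)c3)cc2-c2ccncc2)ccc1Cl` gives 945 nM in this assay, and compound 3 `O=C(Nc1cccc(-n2cc(-c3ccncc3)c(-c3ccc(Cl)c(O)c3)n2)c1)Nc1ccc(Cl)c(Cl)c1` gives 1060 nM. Among the measured compounds shown here, compound 3 stands within the scatter of both others; the only single-point step on record, a 1.1-fold higher number from compound 2 to compound 3 (0.05 log units; within the scatter), is itself within the scatter.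

The next member, compound 4 `O=C(Nc1cccc(-n2cc(-c3ccncc3)c(-c3ccc(Cl)c(O)c3)n2)c1)Nc1ccc(Cl)c(C(F)(F)F)c1`, carries trifluoromethyl in place of chloro on an aromatic carbon. For the measured compounds named here, no measured step tests exactly this exchange. The closest evidence is the pair compound 1 and compound 2, which differ in the number and placement of trifluoromethyl against chloro groups on the same phenyl: compound 1 gives 933 nM and compound 2 gives 945 nM, numbers within the scatter of each other. Swapping chloro and trifluoromethyl on this phenyl has therefore not moved the read-out in this assay so far.

On that basis no step beyond the scatter is expected for compound 4, with a 1.1-fold lower number from compound 3 to compound 4 (0.03 log units; within the scatter) as the estimated change, because compound 1 at 933 nM and compound 2 at 945 nM sit together. Compound 4 is expected to give about 1000 nM in this assay, estimated between 500 nM and 2100 nM.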

Compound 4, concentration for 50% growth inhibition: 663 nM
Compound 4: the middle estimate sits 1.5-fold (0.18 log units) above what was measured; the range from low to high includes it.
By their numbers in this assay, from the lowest: compounds 4, 1, 2 and 3 (each within the scatter of the next).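

The direct exchange of chloro for trifluoromethyl, with the new group ortho to a chloro group and meta to a large group, gives a 1.6-fold lower number from compound 3 to compound 4 (0.20 log units; within the scatter) in this assay. Among these compounds, this is the first single-point reading of this exchange: the change from 3,4-dichlorophenyl to 4-chloro-3-(trifluoromethyl)phenyl, with four heavy atoms entering where one leaves, does not move the read-out beyond the scatter while the rest of compound 3 stays fixed. The data shown offer no independent measurement that could explain the size of this step.

Going by these compounds, it remains open whether the same exchange reads alike with methyl on the oxygen of the other aromatic ring, as in compound 2, since this single step rests on the hydroxy form alone. On these data alone, with compounds 4, 1, 2 and 3 each within the scatter of the next, it also remains open whether a nitrile, an amine or a carboxylic acid at this position would give a step beyond the scatter in this assay.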